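The source may report more compounds than this note shows. Statements on the series, on what has been measured and on what is new or still open speak of the compounds shown alone.

Going by the values given here, compound 2 `CC(NC(=O)CN)C(=O)N(C)c1ccc(Cl)cc1C(=O)c1ccccc1Cl` gives 8.5 mg/kg in a functional assay on the whole organism with Mus musculus as the target, in the rotarod test (a higher number here means that more compound is needed for the effect, a lower number that less compound is needed), the only true number so far. Compound 1 `CN1CCN(CC(=O)NCC(=O)N(C)c2ccc(Cl)cc2C(=O)c2ccccc2Cl)CC1` reaches only a limit, > 100 mg/kg. Compound 3 `CCCCCCC(=O)NCC(=O)N(C)c1ccc(Cl)cc1C(=O)c1ccccc1Cl` carries ((hexylcarbonyl)amino)methyl in place of 1-(((aminomethyl)carbonyl)amino)ethyl on a carbonyl carbon. Among the compounds with values here, no measured step covers this change, so the expectation is loose. A shift beyond the scatter towards a higher dose in this assay is expected, and the estimated step is a 7.1-fold higher number from compound 2 to compound 3 (0.85 log units; beyond the scatter). The expected value for compound 3 is 60 mg/kg, with an estimated range of 15 mg/kg to 200 mg/kg.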

Compound 3, dose for half-maximal effect: 70 mg/kg
For compound 3 the middle estimate is 1.2-fold (0.07 log units) below the measured one; the range from low to high includes it.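

In this assay, ((hexylcarbonyl)amino)methyl in place of 1-(((aminomethyl)carbonyl)amino)ethyl on a carbonyl carbon gives an 8.2-fold higher number from compound 2 to compound 3 (0.92 log units; beyond the scatter), so this position does not tolerate every chain equally. The change from 4-methylpiperazin-1-yl to pentyl gives an at least 1.4-fold lower number from compound 1 to compound 3 (0.15 log units; that floor lies within the scatter), a floor that settles no order. Compound 1 carries a limit, not a number: the limit of > 100 mg/kg in this assay, at which 1 of the 3 values shown sits.

Open, on these data alone, is whether the shift in compound 3 follows the hexylcarbonyl chain or the loss of the methyl on the link. A primary amine on the unbranched link, or a shorter alkyl chain on the branched one, would separate the two.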